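Swapping a chlorophenyl for a chloropyridinyl on the amide

The source may report more compounds than this note shows. Statements on the series, on what has been measured and on what is new or still open speak of the compounds shown alone.

Three compounds share one core and differ only in the group on the amide nitrogen. In a functional assay on U-87MG ATCC cells for inhibition, with U-87 MG (Homo sapiens) as the target, read by MTT assay, with a stated time of 72 h (a lower number here means a stronger inhibitor, a higher number a weaker inhibitor), compound 1 `Cc1noc(C)c1-c1cnc(N)c(Oc2ccc(C(=O)NC3CCCCC3)cc2)n1` gives 40400 nM, compound 2 `Cc1noc(C)c1-c1cnc(N)c(Oc2ccc(C(=O)Nc3ccccc3)cc2)n1` gives 26600 nM, and compound 3 `Cc1noc(C)c1-c1cnc(N)c(Oc2ccc(C(=O)Nc3ccc(Cl)cc3)cc2)n1` gives 15500 nM, the lowest of the three numbers, though a 1.7-fold lower number from compound 2 to compound 3 (0.23 log units; within the scatter) and a 2.6-fold lower number from compound 1 to compound 3 (0.42 log units; beyond the scatter) show only the second gap is clear. Compound 4 `Cc1noc(C)c1-c1cnc(N)c(Oc2ccc(C(=O)Nc3cc(Cl)ccn3)cc2)n1` carries 4-chloropyridin-2-yl in place of 4-chlorophenyl on an amide-type nitrogen. Within the data shown here, no measured step exchanges a ring carbon for a ring nitrogen; the nearest steps, a 2.6-fold lower number from compound 1 to compound 3 (0.42 log units; beyond the scatter) and a 1.7-fold lower number from compound 2 to compound 3 (0.23 log units; within the scatter), were small. For compound 4 the expected step is therefore a 1.0-fold lower number from compound 3 to compound 4 (0.01 log units; within the scatter), none beyond the scatter, giving an estimated 15000 nM with a range from 6000 nM to 40000 nM.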

Compound 4, half-maximal inhibitory concentration: 70800 nM
Estimate against measurement, compound 4: 4.7-fold (0.67 log units) below, outside the stated range (above it).
By their numbers in this assay, from the lowest: compounds 3, 2, 1 and 4 (each within the scatter of the next, the first and the last beyond it).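

Among these compounds, at this amide-type nitrogen, exchanging one ring carbon for nitrogen is not a neutral swap: in this assay, a 4.6-fold higher number from compound 3 to compound 4 (0.66 log units; beyond the scatter) is the largest step so far. The 4-chloropyridin-2-yl group also gives up the position of the plain phenyl, with a 2.7-fold higher number from compound 2 to compound 4 (0.43 log units; beyond the scatter). Against the cyclohexyl group, a 1.8-fold higher number from compound 1 to compound 4 (0.24 log units; within the scatter) leaves no clear difference. Nothing in the data explains this loss. Also open, on these data alone, is how a plain pyridin-2-yl group, without the chlorine, would read on this nitrogen.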